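One Ester Group Changed on a Shared Core

The source may report more compounds than this note shows. Statements on the series, on what has been measured and on what is new or still open speak of the compounds shown alone.

Three compounds sharing one core have been measured in an ADME assay on a cell-free system (plasma, Homo sapiens) for metabolic stability, with Plasma (Rattus norvegicus) as the target, read by HPLC, at pH 7.4; on this read-out lower numbers stand for a shorter-lived compound and higher numbers for a longer-lived compound:

Compound 1, `CC(=O)Oc1ccccc1C(=O)O[C@H]1CO[C@H]2[C@@H]1OC[C@H]2OC(=O)c1ccnn1C`, gives 0.0963 h.
Compound 2, `CC(=O)Oc1ccccc1C(=O)O[C@H]1CO[C@H]2[C@@H]1OC[C@H]2OC(C)=O`, gives 0.0608 h.
Compound 3, `CCC(=O)O[C@@H]1CO[C@H]2[C@@H]1OC[C@@H]2OC(=O)c1ccccc1OC(C)=O`, gives 0.0608 h.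

Compound 1 has the highest of the three numbers, yet it is not set apart: the step of a 1.6-fold lower number from compound 1 to compound 2 (0.20 log units; within the scatter) and the step of a 1.6-fold lower number from compound 1 to compound 3 (0.20 log units; within the scatter) are both within the scatter, as is the step of no change at the digits printed from compound 2 to compound 3 (within the scatter). The three compounds are therefore indistinguishable on this read-out.

Compound 4, `COc1ccccc1C(=O)O[C@@H]1CO[C@H]2[C@@H]1OC[C@@H]2OC(=O)c1ccccc1OC(C)=O`, has not yet been measured. It differs from compound 1 in one place: 2-methoxyphenyl in place of 1-methyl-1H-pyrazol-5-yl on a carbonyl carbon.

Going by the values given here, two measured steps bear on this change. Both also replace the 1-methyl-1H-pyrazol-5-yl group on that carbonyl carbon: the step of a 1.6-fold lower number from compound 1 to compound 2 (0.20 log units; within the scatter) brings in methyl and the step of a 1.6-fold lower number from compound 1 to compound 3 (0.20 log units; within the scatter) brings in ethyl, and neither moved the number beyond the scatter. Among the compounds with values here, no measured step brings in a six-membered aromatic ring, so the data say nothing specific about 2-methoxyphenyl. Within the data shown here, with replacement at this position having produced only scatter-sized steps so far, the expectation for compound 4 is a step of about a 1.2-fold lower number from compound 1 to compound 4 (0.08 log units; within the scatter), that is none beyond the scatter. Compound 4 is thus estimated at 0.08 h, with a range from 0.04 h to 0.2 h.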

Compound 4, half-life: 0.0578 h
For compound 4 the middle estimate is 1.4-fold (0.14 log units) above the measured one; the measured number falls inside the stated range.
By their numbers in this assay, from the lowest: compounds 4, 2, 3 and 1 (each within the scatter of the next).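

In this assay, the pattern at this carbonyl carbon now reaches beyond a five-membered aromatic ring and two small chains: 2-methoxyphenyl, a six-membered aromatic ring of carbon only, in place of 1-methyl-1H-pyrazol-5-yl gives a 1.7-fold lower number from compound 1 to compound 4 (0.22 log units; within the scatter). Set against the small chains, the same group gives a 1.1-fold lower number from compound 2 to compound 4 (0.02 log units; within the scatter) when it replaces methyl and a 1.1-fold lower number from compound 3 to compound 4 (0.02 log units; within the scatter) when it replaces ethyl, so all four compounds remain indistinguishable on this read-out, and swapping this group for a larger aromatic one has not moved the half-life beyond the scatter. No measurement is available that would explain why these different groups give such similar numbers.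

Going by these compounds, whether an amine, a carboxylic acid or a longer chain at this position would give a step beyond the scatter remains open. On these data alone, the second ester on the shared core, which carries the acetyl group on its benzene ring, is the same in all four compounds, so the effect of changing that part on the half-life also remains unknown.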